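The source may report more compounds than this note shows. Statements on the series, on what has been measured and on what is new or still open speak of the compounds shown alone.

Compound 1 `O=c1[nH]ccn1CCOc1nn(-c2ccccc2F)c2ccc(F)cc12` gives 200 mL/min/kg in an ADME assay on liver for metabolic stability, with Liver microsome (Homo sapiens) as the target, using microsomes and NADPH, with a stated time of 30 min, tested at 0.5 uM; on this read-out higher numbers stand for fast clearance and lower numbers for slow clearance; compound 2 `CN1CCN(CCOc2nn(-c3ccccc3F)c3ccc(F)cc23)C1=O` gives 1000 mL/min/kg; compound 3 `O=C1NCCN1CCOc1nn(-c2ccccc2F)c2ccc(F)cc12` gives 183 mL/min/kg.

Compound 3 stands lowest of the three numbers, though its gap to compound 1 lies within the scatter a 1.1-fold lower number from compound 1 to compound 3 (0.04 log units; within the scatter), while compound 2 sits well above it a 5.5-fold lower number from compound 2 to compound 3 (0.74 log units; beyond the scatter). Compound 4 `O=C(COc1nn(-c2ccccc2F)c2ccc(F)cc12)N1CCOCC1` differs from compound 3 by (morpholin-4-yl)carbonyl in place of (2-oxoimidazolidin-1-yl)methyl on a saturated chain carbon bound to an oxygen on an aromatic ring. Among the measured compounds shown here, no measured step covers this exchange; the nearest hints are a 5.0-fold higher number from compound 1 to compound 2 (0.70 log units; beyond the scatter) and a 5.5-fold lower number from compound 2 to compound 3 (0.74 log units; beyond the scatter), which show that changes on this chain end can shift the read-out modestly in either direction. Compound 4 is therefore expected to lie near compound 3 or somewhat higher, estimated at 300 mL/min/kg (range 120 mL/min/kg to 800 mL/min/kg), an expected step of a 1.6-fold higher number from compound 3 to compound 4 (0.21 log units; within the scatter).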

Compound 4, clearance: 117 mL/min/kg
The estimate for compound 4 lay 2.6-fold (0.41 log units) above the measured number, outside the stated range (below it).
By their numbers in this assay, from the lowest: compounds 4, 3 and 1 (each within the scatter of the next); then compound 2.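

In this assay the (morpholin-4-yl)carbonyl group on this saturated chain carbon reads level with the (2-oxoimidazolidin-1-yl)methyl group (a 1.6-fold lower number from compound 3 to compound 4 (0.19 log units; within the scatter)) and with the aromatic ring group of compound 1 (a 1.7-fold lower number from compound 1 to compound 4 (0.23 log units; within the scatter)). Only compound 2 stands apart (an 8.5-fold lower number from compound 2 to compound 4 (0.93 log units; beyond the scatter)), so a six-membered ring joined through a carbonyl also fits this position without the high number seen with compound 2. Nothing measured here gives a reason for this. As far as these compounds go, whether an amine such as piperidin-1-yl in place of the morpholine would hold this number remains open, as does the effect of a longer chain.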